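Benzofuranyl in place of thiophenyl on the nucleoside core

This account rests on a few compounds, and the source may have more. Where it says the series, first, only, none or still open, it means among the compounds named here.

Measured so far in a functional assay on HCT-116 cells (Homo sapiens), read by MTT assay, with a stated time of 72 h; on this read-out lower numbers stand for stronger inhibition and higher numbers for weaker inhibition:
compound 1 `O=c1[nH]cnc2c1c(-c1cccs1)cn2[C@@H]1O[C@H](CO)[C@@H](O)[C@H]1O` > 20000 nM
compound 2 `O=c1[nH]cnc2c1c(-c1ccsc1)cn2[C@@H]1O[C@H](CO)[C@@H](O)[C@H]1O` > 20000 nM
compound 3 `CNc1ncnc2c1c(I)cn2[C@@H]1O[C@H](CO)[C@@H](O)[C@H]1O` > 100000 nM

Compound 2 stands only at a limit of this assay, > 20000 nM. The two other values shown are limits as well, as the limit of > 20000 nM in this assay, at which 2 of the 3 values shown sit, and the limit of > 100000 nM in this assay, at which 1 of the 3 values shown sits, record. For the measured compounds named here, the one step between measured compounds, a step that the two limits leave unreadable from compound 1 to compound 2, is thus left unreadable by the limits on both sides.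

Compound 4 `O=c1[nH]cnc2c1c(-c1cc3ccccc3o1)cn2[C@@H]1O[C@H](CO)[C@@H](O)[C@H]1O` differs from compound 2 by 1-benzofuran-2-yl in place of thiophen-3-yl on an aromatic carbon. Going by the values given here, no measured step bears readably on this change, so no shift beyond the scatter can be expected in this assay, and a further limit is the likeliest outcome. Compound 4 is therefore estimated at 35000 nM in this assay, within 8000 nM to 100000 nM, a step that the limit leaves unreadable from compound 2 to compound 4 that is expected, not measured.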

Compound 4, half-maximal inhibitory concentration: > 20000 nM
Compound 4: only a limit was reported; the forecaster's own chance of this, stated with the estimate: 70%; the middle value lies beyond the limit too.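

In this assay compound 4 gives > 20000 nM, a limit, so its steps from compound 1 and compound 2 cannot be read: the limit of > 20000 nM in this assay, at which 3 of the 4 values shown sit.

The compounds shown leave open whether any group on this aromatic carbon of the shared core gives a measurable value in this assay.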